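Working notes: propyl in place of cyclopentyl

The source may report more compounds than this note shows. Statements on the series, on what has been measured and on what is new or still open speak of the compounds shown alone.

Measured in an ADME assay on the whole organism (plasma, Mus musculus, strain CD-1) for protein binding, read by LC-MS, with a stated time of 24 h; on this read-out lower numbers stand for a smaller free fraction and higher numbers for a larger free fraction:
- compound 1 `Cc1nc(-c2nnn(C)c2COC(=O)N(C)CC2CCC2)ccc1O[C@H]1CCC[C@H](C(=O)O)C1`: 0.1
- compound 2 `Cc1nc(-c2nnn(C)c2COC(=O)N(C)CC2CCCC2)ccc1O[C@H]1CCC[C@H](C(=O)O)C1`: 0.065

Going by the values given here, compound 2 stands within the scatter of compound 1, the only other measured compound. Compound 3 `CCCCN(C)C(=O)OCc1c(-c2ccc(O[C@H]3CCC[C@H](C(=O)O)C3)c(C)n2)nnn1C` is still unmeasured. The structural change is propyl in place of cyclopentyl on a saturated chain carbon bound to an amide-type nitrogen, with propyl in place of cyclopentyl on a saturated chain carbon bound to an amide-type nitrogen. Among the compounds with values here, one measured step bears on it, at the same place: a 1.5-fold lower number from compound 1 to compound 2 (0.19 log units; within the scatter). That step stays within the scatter, so no step beyond the scatter is expected in this assay. The expected step is a 1.4-fold higher number from compound 2 to compound 3 (0.14 log units; within the scatter). The estimate for compound 3 is 0.09, with an expected range of 0.05 to 0.17.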

Compound 3, unbound fraction: 0.134
Compound 3: the middle estimate sits 1.5-fold (0.17 log units) below what was measured; the range from low to high includes it.
By their numbers in this assay, from the lowest: compounds 2, 1 and 3 (each within the scatter of the next, the first and the last beyond it).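

In this assay, going by these compounds alone, the change from cyclopentyl to propyl gives a 2.1-fold higher number from compound 2 to compound 3 (0.31 log units; beyond the scatter) and is the only step in this set that clears the scatter. The change from cyclobutyl to propyl gives a 1.3-fold higher number from compound 1 to compound 3 (0.13 log units; within the scatter) and does not separate the two compounds. At this place on a saturated chain carbon bound to an amide-type nitrogen, only the cyclopentyl and propyl compounds are therefore told apart. Going by these compounds, whether a longer chain or an ether oxygen in the chain would hold or shift the free fraction remains open. No measurement shown accounts for the step.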